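The source may report more compounds than this note shows. Statements on the series, on what has been measured and on what is new or still open speak of the compounds shown alone.

The measured compounds are:

compound 1, `CCc1nnc(O)n2c(C(C)CC)nc(C)c12` — 45000 nM
compound 2, `CCc1nnc(S)n2c(C(C)CC)nc(C)c12` — > 48000 nM
compound 3, `CCc1nc(C)c2cnnc(O)n12` — > 48000 nM

All three were tested in a functional assay for inhibition, with Homo sapiens as the target; a higher number here means a weaker inhibitor, a lower number a stronger inhibitor. In this assay compound 1 gives 45000 nM. For compound 2 the assay reports only a limit, > 48000 nM, and not a number. For compound 3 the assay likewise reports only a limit, > 48000 nM.

Compound 2 is obtained from compound 1 by the change (sulfanyl in place of hydroxy on an aromatic carbon). The step it made is an at least 1.0-fold higher number from compound 1 to compound 2 (0.02 log units; that floor lies within the scatter), and because the limit of > 48000 nM in this assay, at which 2 of the 3 values shown sit, the measured side of this pair gives no finer reading of the change than that.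

Compound 3 carries a different core from compound 1; the difference between the two cores is not broken down here. The unmeasured compound 4, `CCc1nc(C)c2cnnc(S)n12`, stands to compound 3 as compound 2 stands to compound 1: the change is sulfanyl in place of hydroxy on an aromatic carbon. The surroundings of the place are not identical, since in compound 1 the carbon is also para to an ethyl group (2 heavy atoms), which is absent in compound 3, so this is the same kind of change rather than the same change.

For compound 4 a step that the limit leaves unreadable from compound 3 to compound 4 in this assay is expected, resting on the step of an at least 1.0-fold higher number from compound 1 to compound 2 (0.02 log units; that floor lies within the scatter) and on the fact that compound 3 already sits at the limit > 48000 nM. The value of compound 4 in this assay is therefore estimated at 60000 nM, with a plausible range from 30000 nM to 150000 nM, and most likely the assay will again report only a limit.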

Compound 4, half-maximal inhibitory concentration: > 48000 nM
Compound 4 ended at the assay's limit; the forecaster's own chance of this, stated with the estimate: 85%; the middle value is on the limit's open side.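

In this assay compound 4 gives > 48000 nM, which is a limit and not a number. Compound 3 stands at a limit too, so no step can be read from compound 3 to compound 4: the limit of > 48000 nM in this assay, at which 3 of the 4 values shown sit.

The compounds shown leave open whether sulfanyl in place of hydroxy on an aromatic carbon changes the read-out at all, and where the true values of compound 2, compound 3 and compound 4 lie.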